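Branching the butyl chain: what to expect for compound 3

The source may report more compounds than this note shows. Statements on the series, on what has been measured and on what is new or still open speak of the compounds shown alone.

Measured compounds:
compound 1, `CCCCc1nc(=O)c(S(=O)(=O)c2ccc(-c3ccc(F)cc3)cc2)c(O)n1-c1c(OC)cccc1OC`, in an ADME assay on microsomes from liver (Rattus norvegicus) for metabolic stability, using NADPH, with a stated time of 10 min (a higher number here means that more of the compound is left, a lower number that less of the compound is left), gives 5%
compound 2, `CCCCc1nc(=O)c(S(=O)(=O)c2ccc(-c3ccc(F)nc3)cc2)c(O)n1-c1c(OC)cccc1OC`, in this assay gives 2%

Compound 2 holds the lowest of the two numbers, but the step of a number 3 percentage points lower from compound 1 to compound 2 (within the scatter) is within the scatter, so compound 1 and compound 2 cannot be told apart on this read-out. Both leave little of the compound after the incubation.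

Compound 3, `COc1cccc(OC)c1-n1c(CCC(C)C)nc(=O)c(S(=O)(=O)c2ccc(-c3ccc(F)nc3)cc2)c1O`, differs from compound 2 in one place: methyl in place of hydrogen on a saturated chain carbon bound to two saturated chain carbons. Within the data shown here, the only measured step, from compound 1 to compound 2, concerns the aromatic ring and says nothing about the chain, so no measured step bears on this change. With nothing to point elsewhere, the step of a number 2 percentage points higher from compound 2 to compound 3 (within the scatter) is expected to stay within the scatter. Compound 3 is therefore estimated at 4% in this assay, with a range from 0% to 15%.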

Compound 3, percent of the compound remaining: 1%
Beside the measured number, compound 3's estimate is 3 percentage points above it, within the range that was stated.
By their numbers in this assay, from the lowest: compounds 3, 2 and 1 (each within the scatter of the next).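

Placing a methyl on this saturated chain carbon, which turns butyl into isopentyl, gives a number 1 percentage points lower from compound 2 to compound 3 (within the scatter) in this assay, so compound 2 and compound 3 cannot be told apart on this read-out. Among these compounds, this is the first look at the chain rather than the aromatic ring, and this single branch does not lift the number clear of the scatter, with little of the compound left in either case. No measurement shown here offers an explanation for this result.

All three compounds sit so low that a further loss would hardly register, so the read-out can show little beyond whether a change brings a clear gain. As far as these compounds go, whether a chain carrying an amine or a carboxylic acid, or a shorter chain such as ethyl, would leave more of the compound stays open.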